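Cyano in place of methoxy on the aryl triazole

The compounds below may be only part of what the source reports. "The series", "measured", "known", "first", "only" and "open" are said of these compounds alone.

Three compounds share one core and differ only in the group on the phenyl ring of the triazole. Compound 1 `Cc1ccccc1-n1cc(CN2C(=O)C[C@@H]3CC[C@@]2(C)C3(C)C)nn1` gives 150 nM in a functional assay on OVCAR-3 cells (Homo sapiens) for inhibition, read by MTT assay, with a stated time of 24 h; on this read-out higher numbers stand for weaker inhibition and lower numbers for stronger inhibition. Compound 2 `CC1(C)[C@H]2CC[C@]1(C)N(Cc1cn(-c3ccccc3O)nn1)C(=O)C2` gives 90 nM in the same assay, and compound 3 `COc1ccccc1-n1cc(CN2C(=O)C[C@@H]3CC[C@@]2(C)C3(C)C)nn1` gives 140 nM. Compound 3 thus holds the second highest of the three numbers, nearest to compound 1 and furthest from compound 2, with both gaps within the scatter. The steps recorded so far, a 1.1-fold lower number from compound 1 to compound 3 (0.03 log units; within the scatter) and a 1.6-fold higher number from compound 2 to compound 3 (0.19 log units; within the scatter), together with a 1.7-fold lower number from compound 1 to compound 2 (0.22 log units; within the scatter), all stay within the scatter.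

Compound 4 `CC1(C)[C@H]2CC[C@]1(C)N(Cc1cn(-c3ccccc3C#N)nn1)C(=O)C2` differs from compound 3 in this way: cyano in place of methoxy on an aromatic carbon. Among the compounds with values here, no measured step touches a cyano group, so the bearing steps are only those above, none of which moved the number beyond the scatter. The expected step is therefore no change at the digits printed from compound 3 to compound 4 (within the scatter), none beyond the scatter. Compound 4 is accordingly estimated at 140 nM, with a range from 50 nM to 400 nM.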

Compound 4, half-maximal inhibitory concentration: 110 nM
For compound 4 the middle estimate is 1.3-fold (0.10 log units) above the measured one, within the range that was stated.
By their numbers in this assay, from the lowest: compounds 2, 4, 3 and 1 (each within the scatter of the next).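

With a cyano group, this place on the aromatic ring, ortho to a large group, has now carried four different groups, and in this assay all of them stay within the scatter of one another. Within the data shown here, this holds for the exchange of methoxy (a 1.3-fold lower number from compound 3 to compound 4 (0.10 log units; within the scatter)), of hydroxy (a 1.2-fold higher number from compound 2 to compound 4 (0.09 log units; within the scatter)) and of methyl (a 1.4-fold lower number from compound 1 to compound 4 (0.13 log units; within the scatter)), so the entering triple bond sets no compound apart on this read-out. No measurement on hand bears on why the four groups read alike.

On these data alone, whether any group at this place can move the number beyond the scatter stays open, for instance an amine, a carboxylic acid or a longer chain. Also open, as far as these compounds go, is whether cyano would read the same at another carbon of the ring.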